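Replacing a Benzyl Linker with a Direct Aryl Bond

The compounds below may be only part of what the source reports. "The series", "measured", "known", "first", "only" and "open" are said of these compounds alone.

The measured compounds:
compound 1, `C=C(Br)C(=O)Nc1cccc(-c2cn3nc(Cc4cccc(OC)c4)sc3n2)c1`: 2500 nM
compound 2, `Nc1cccc(-c2cn3nc(Cc4ccccc4)sc3n2)c1`: 24000 nM
compound 3, `COc1ccc(-c2nn3cc(-c4cccc(N)c4)nc3s2)cc1OC`: 26000 nM

All three were tested in a functional assay on HeLa cells (Homo sapiens) for inhibition, read by cell counting, with a stated time of 4 days; on this read-out higher numbers stand for weaker inhibition and lower numbers for stronger inhibition. Compound 1 gives the lowest number of the three, and both gaps to the others are beyond the scatter: compound 2 sits a good deal higher and compound 3 higher still. Compound 1 is therefore the strongest inhibitor among these, while compound 2 and compound 3 are close to each other.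

Compound 4, `C=C(Br)C(=O)Nc1cccc(-c2cn3nc(-c4cccc(OC)c4)sc3n2)c1`, has not yet been measured. It differs from compound 1 in one place: 3-methoxyphenyl in place of 3-methoxybenzyl on an aromatic carbon. In plain terms, the ring that carried a methoxy group is now attached directly to the shared core instead of through a single carbon.

Among the measured compounds shown here, no pair of measured compounds shows this exact change. Compound 2 and compound 3 each carry an amine rather than the bromoacrylamide, and compound 3 carries two methoxy groups, so they give only a loose hint: the two values are close despite their different linkers. On that basis the expected step from compound 1 to compound 4 in this assay is a 1.2-fold higher number from compound 1 to compound 4 (0.08 log units; within the scatter), which is not beyond the scatter.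

Compound 4 is accordingly estimated at 3000 nM, with a likely range from 1000 nM to 9000 nM.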

Compound 4, half-maximal inhibitory concentration: 1100 nM
Beside the measured number, compound 4's estimate is 2.7-fold (0.44 log units) above it; measured number inside the range.
By their numbers in this assay, from the lowest: compound 4; then compound 1; then compounds 2 and 3 (each within the scatter of the next).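

Attaching the 3-methoxyphenyl ring directly to the shared core gives a 2.3-fold lower number from compound 1 to compound 4 (0.36 log units; beyond the scatter) in this assay and shows that, on this carbon of the five-membered aromatic ring, the single carbon of the 3-methoxybenzyl group is not needed for inhibition in these cells. The step is modest, but it lies beyond the scatter, so the shorter attachment is a real if small improvement for this pair. The earlier compounds shown here could not show this, since no two of them differed in one place only, whereas compound 1 and compound 4 share the bromoacrylamide and the methoxy group and differ only in how the ring is attached.

The compounds shown leave open whether a longer chain in place of the 3-methoxybenzyl link, or a hydroxyl group or a carboxylic acid in place of the methoxy group, would keep, improve or lose this level of inhibition. Nothing shown here speaks to the reason that the directly attached ring gives the lower number.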